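The source may report more compounds than this note shows. Statements on the series, on what has been measured and on what is new or still open speak of the compounds shown alone.

Within the data shown here, compound 2 `CCN(C/C=C/C#CC(C)(C)C)Cc1cccc(OCCN(C)S(=O)(=O)Cc2cccs2)c1` gives 200 nM in a functional assay on HepG2 cells for inhibition of squalene monooxygenase (Homo sapiens) (on this read-out lower numbers stand for stronger inhibition and higher numbers for weaker inhibition), the second highest of the three numbers measured so far: compound 1 `CCN(C/C=C/C#CC(C)(C)C)Cc1cccc(OCCN(C)S(=O)(=O)c2ccsc2)c1` gives 250 nM, and compound 3 `CCN(C/C=C/C#CC(C)(C)C)Cc1cccc(OCCN(C)S(=O)(=O)c2cc(-c3ccsc3)cs2)c1` gives 90 nM. The step of a 1.3-fold lower number from compound 1 to compound 2 (0.10 log units; within the scatter) lies within the scatter, whereas a 2.2-fold lower number from compound 2 to compound 3 (0.35 log units; beyond the scatter) and a 2.8-fold lower number from compound 1 to compound 3 (0.44 log units; beyond the scatter) are modest. Compound 4 `CCN(C/C=C/C#CC(C)(C)C)Cc1cccc(OCCCN(C)S(=O)(=O)c2cccs2)c1` holds the same atoms joined differently: a group of 11 heavy atoms (6 carbon, 1 nitrogen, 2 oxygen, 2 sulfur; one five-membered aromatic ring with 1 hetero atom) in place of a group of 11 heavy atoms (6 carbon, 1 nitrogen, 2 oxygen, 2 sulfur; one five-membered aromatic ring with 1 hetero atom), on a saturated chain carbon, two bonds along the chain from an oxygen on an aromatic ring. Among the measured compounds shown here, none of the measured steps touches the chain itself; the only comparably small change at the sulfonyl sulfur, a 1.3-fold lower number from compound 1 to compound 2 (0.10 log units; within the scatter), stayed within the scatter, so no step beyond the scatter is expected in this assay either way. Compound 4 is therefore estimated at 200 nM, in a range from 80 nM to 500 nM, which means an expected step of no change at the digits printed from compound 2 to compound 4 (within the scatter).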

Compound 4, half-maximal inhibitory concentration: 6400 nM
Compound 4: the middle estimate sits 32-fold (1.51 log units) below what was measured; the measured number lies above the stated range.
By their numbers in this assay, from the lowest: compound 3; then compounds 2 and 1 (each within the scatter of the next); then compound 4.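

In this assay, placing (methyl((thiophen-2-yl)sulfonyl)amino)methyl on the saturated chain carbon, two bonds along the chain from an oxygen on an aromatic ring, brings a 32-fold higher number from compound 2 to compound 4 (1.51 log units; beyond the scatter) and a 26-fold higher number from compound 1 to compound 4 (1.41 log units; beyond the scatter). The earlier compounds shown here, which varied only at the sulfonyl sulfur, moved this read-out modestly at most, whereas this position proves far less tolerant, even with the atoms of compound 2 only joined differently. Nothing available here explains a step of this size.

The compounds shown leave open how much of the loss belongs to the chain and how much to the thiophen-2-yl on the sulfonyl sulfur. From the compounds shown here alone, whether an amine or a carboxylic acid at this carbon would restore inhibition also remains open.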